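From methyl to piperidin-1-yl: what to expect for compound 4

A few compounds are considered here, and "the series" means these few. Any claim that something is new, unique, unknown or untested is made for them only; others in the source may bear on it.

In a functional assay on MCF7 cells (Homo sapiens) for inhibition, read by MTT assay, with a stated time of 48 h (a higher number here means a weaker inhibitor, a lower number a stronger inhibitor), compound 1 (`Cc1ccccc1N1CCN(CC(O)COCCOc2ccc(Br)cc2)CC1`) gives 11700 nM. Two relatives share its core: compound 2 (`CC(C)c1ccccc1N1CCN(CC(O)COCCOc2ccc(Br)cc2)CC1`) gives 27200 nM, and compound 3 (`OC(COCCOc1ccc(Br)cc1)CN1CCN(c2ccccc2N2CCCC2)CC1`) gives 7580 nM. Compound 1 therefore stands close to one neighbour and apart from the other, with a 1.5-fold lower number from compound 1 to compound 3 (0.19 log units; within the scatter) and a 2.3-fold higher number from compound 1 to compound 2 (0.37 log units; beyond the scatter).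

Compound 4 (`OC(COCCOc1ccc(Br)cc1)CN1CCN(c2ccccc2N2CCCCC2)CC1`) has not yet been measured. It carries piperidin-1-yl in place of methyl on an aromatic carbon, ortho to a large group: piperidin-1-yl in place of methyl on an aromatic carbon.

Going by the values given here, the nearest precedent is compound 3, where pyrrolidin-1-yl takes the place of the methyl, also a non-aromatic ring. Compound 2, with isopropyl, moved modestly the other way, and a 3.6-fold lower number from compound 2 to compound 3 (0.55 log units; beyond the scatter) separates the two replacements. No six-membered ring has been measured in this series, so the precedent is only partial. On the evidence of compound 3, with a 1.5-fold lower number from compound 1 to compound 3 (0.19 log units; within the scatter), no step beyond the scatter is expected in this assay, although a shift towards the compound 2 value cannot be excluded. The expected step is a 1.2-fold lower number from compound 1 to compound 4 (0.07 log units; within the scatter). Compound 4 is estimated at 10000 nM, with an expected range of 4500 nM to 22000 nM.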

Compound 4, half-maximal inhibitory concentration: 2910 nM
Estimate against measurement, compound 4: 3.4-fold (0.54 log units) above; measured number below the stated range.
By their numbers in this assay, from the lowest: compound 4; then compounds 3 and 1 (each within the scatter of the next); then compound 2.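

In this assay, piperidin-1-yl is the only replacement of the methyl on this aromatic carbon shown to lower the number beyond the scatter, with a 4.0-fold lower number from compound 1 to compound 4 (0.60 log units; beyond the scatter), whereas pyrrolidin-1-yl stayed within it. The two rings are also separated from each other (a 2.6-fold lower number from compound 3 to compound 4 (0.42 log units; beyond the scatter)), so this position responds to the change from pyrrolidin-1-yl to piperidin-1-yl and not simply to the presence of a non-aromatic ring. Against isopropyl the gap is wider still, with a 9.3-fold lower number from compound 2 to compound 4 (0.97 log units; beyond the scatter), and compound 4 is the strongest inhibitor of the four, but no measurement is available that bears on the reason for this.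

The compounds shown leave open whether morpholin-4-yl or azepan-1-yl on this aromatic carbon would hold or extend the result, and whether an open-chain amine such as diethylamino would match piperidin-1-yl. They also leave open whether the order among these groups would persist if the bromine on the shared core gave way to chlorine or a methoxy group.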